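Removing a methyl from a thiosemicarbazide amidine pair

The source may report more compounds than this note shows. Statements on the series, on what has been measured and on what is new or still open speak of the compounds shown alone.

Measured compounds:
compound 1, `N/C(=N\NC(=S)N1CCCC1)c1ccc(F)cn1`, 78.7%
compound 2, `Cc1cccc(/C(N)=N/NC(=S)N2CCSCC2)n1`, 53.2%

In a functional assay on A-431 cells (Homo sapiens) for cytotoxicity, read by MTT assay, with a stated time of 72 h, tested at 10 uM (on this read-out higher numbers stand for more inhibition of growth at the one concentration tested and lower numbers for less inhibition of growth), compound 1 gives 78.7% and compound 2 gives 53.2%, so compound 2 stands lowest of the two numbers, beyond the scatter below compound 1. Compound 3, `N/C(=N\NC(=S)N1CCSCC1)c1ccccn1`, is not yet measured in this assay. It differs from compound 2 by hydrogen in place of methyl on an aromatic carbon. For the measured compounds named here, no measured pair shows this change alone, so the expected step of a number 2.8 percentage points higher from compound 2 to compound 3 (within the scatter) is none beyond the scatter. Compound 3 is therefore expected to give about 56%, between 30% and 80%.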

Compound 3, percent growth inhibition at one concentration: 61.4%
Estimate against measurement, compound 3: 5.4 percentage points below, within the range that was stated.
By their numbers in this assay, from the lowest: compounds 2 and 3 (each within the scatter of the next); then compound 1.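

In this assay, for the compounds shown here, hydrogen in place of methyl on the aromatic carbon next to the ring nitrogen gives a number 8.2 percentage points higher from compound 2 to compound 3 (within the scatter), the first reading of this change alone. Compound 2 and compound 3 cannot be told apart on this read-out, so growth inhibition at this position does not depend on the methyl. Nothing measured here accounts for this step. On these data alone, whether an ethyl, a methoxy or an amine at the same position would read alike remains open. So does whether the same change would read alike on the core of compound 1.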